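Aryl exchange at the shared core of compound 1

A few compounds are considered here, and "the series" means these few. Any claim that something is new, unique, unknown or untested is made for them only; others in the source may bear on it.

Measured compounds:
compound 1 `Cc1ccc(Nc2nc(Cl)nc3c2ncn3Cc2ccc(C(=O)Nc3ccccc3N)cc2)cc1` — 67.3%
compound 2 `CC(C)n1cnc2c(NCc3ccc(C(=O)Nc4ccccc4N)cc3)nc(Cl)nc21` — 54.2%

In a functional assay on NCI-H460 cells (Homo sapiens) for antiproliferative activity, read by CCK-8 assay, with a stated time of 72 h, tested at 2 uM (a higher number here means a stronger effect of the compound at the concentration tested, a lower number a weaker effect), compound 1 gives 67.3%, the highest of the two numbers available. Going by the values given here, compound 2 gives 54.2% in this assay, a number lower than that of compound 1 by more than the scatter; compound 2 differs from compound 1 in more than one place, so no single step between measured compounds is available.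

Compound 3 `Nc1ccccc1NC(=O)c1ccc(Cn2cnc3c(Nc4cccc(OC(F)(F)F)c4)nc(Cl)nc32)cc1` differs from compound 1 by 3-(trifluoromethoxy)phenyl in place of 4-methylphenyl on a nitrogen on an aromatic ring. Among the compounds with values here, no measured pair covers this kind of change, so its effect cannot be read from the two numbers at hand. The expected step of a number 4.3 percentage points lower from compound 1 to compound 3 (within the scatter) is therefore small, within the scatter and without a clear direction, with a wide range allowed. Compound 3 is estimated at 63%, between 45% and 78%.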

Compound 3, a percentage reported as inhibition, at one concentration (the size of the read-out at that concentration, not a potency): 47.7%
Compound 3: the middle estimate sits 15.3 percentage points above what was measured, within the range that was stated.
By their numbers in this assay, from the lowest: compounds 3 and 2 (each within the scatter of the next); then compound 1.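

Going by these compounds alone, the aryl group on the nitrogen of the shared core is not a silent position in this assay: 3-(trifluoromethoxy)phenyl in place of 4-methylphenyl gives (a number 19.6 percentage points lower from compound 1 to compound 3 (beyond the scatter)), the first single change that can be read. For this one pair, 4-methylphenyl is the better of the two groups, so the position responds to the aryl exchange, though one pair sets no trend. Nothing at hand shows which part of the exchange carries the step.

The step joins a change of substituent with a change of its place on the ring, and 3-methylphenyl or 4-(trifluoromethoxy)phenyl on the same nitrogen would separate the two. Also open, going by these compounds, is how unsubstituted phenyl, or a phenyl carrying an amine, would read against compound 1 at this position.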